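The source may report more compounds than this note shows. Statements on the series, on what has been measured and on what is new or still open speak of the compounds shown alone.

In a functional assay on MCF7 cells (Homo sapiens) for cytotoxicity, read by MTT assay, with a stated time of 72 h (on this read-out lower numbers stand for stronger inhibition and higher numbers for weaker inhibition), the measured compounds are:
Compound 1 `O=C1C(=Cc2ccc(Cl)cc2)C(=O)N(c2ccc(Cl)cc2)N1c1ccc(Cl)cc1`: 28500 nM
Compound 2 `COc1cc(C=C2C(=O)N(c3ccc(Cl)cc3)N(c3ccc(Cl)cc3)C2=O)ccc1O`: 22800 nM
Compound 3 `COc1ccc(C=C2C(=O)N(c3ccc(Cl)cc3)N(c3ccc(Cl)cc3)C2=O)cc1`: > 128000 nM (a limit)

Compound 3 gives no number, only a limit: the limit of > 128000 nM in this assay, at which 1 of the 3 values shown sits. Compound 4 `COc1ccccc1C=C1C(=O)N(c2ccc(Cl)cc2)N(c2ccc(Cl)cc2)C1=O` has the same atoms joined differently: 2-methoxyphenyl in place of 4-methoxyphenyl on a double-bonded chain carbon bound to a double-bonded ring carbon. The nearest measured changes at this place are an at least 4.4-fold higher number from compound 1 to compound 3 (0.65 log units; beyond the scatter) and an at least 5.6-fold higher number from compound 2 to compound 3 (0.74 log units; beyond the scatter), both beyond the scatter, whereas a 1.3-fold lower number from compound 1 to compound 2 (0.10 log units; within the scatter) lies within it. Going by the values given here, none of them moves a methoxy group, so they show only that the group at this place can shift the number. A modest move toward lower numbers is therefore expected, though compound 4 may also return only a limit. The expected step is an at least 1.8-fold lower number from compound 3 to compound 4 (0.26 log units; that floor lies within the scatter). Compound 4 is estimated at 70000 nM, with an expected range of 25000 nM to 180000 nM.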

Compound 4, half-maximal inhibitory concentration: 26300 nM
Compound 4: the middle estimate sits 2.7-fold (0.43 log units) above what was measured; the range from low to high includes it.
By their numbers in this assay, from the lowest: compounds 2, 4 and 1 (each within the scatter of the next). At a limit, above all of these: compound 3.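

Going by these compounds alone, the earlier compounds showed only that the group at this place can shift the number; this pair, with the same atoms joined differently, shows that the arrangement alone can do so: in this assay, 2-methoxyphenyl in place of 4-methoxyphenyl gives an at least 4.8-fold lower number from compound 3 to compound 4 (0.68 log units; beyond the scatter). Compound 3 stands only at a limit: the limit of > 128000 nM in this assay, at which 1 of the 4 values shown sits.

The other steps, a 1.2-fold higher number from compound 2 to compound 4 (0.06 log units; within the scatter) and a 1.1-fold lower number from compound 1 to compound 4 (0.03 log units; within the scatter), both lie within the scatter, so these three groups cannot be told apart here.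

On these data alone, how far compound 3 truly lies from compound 4 stays open, since only a floor is given. Also open, as far as these compounds go, is whether an amine or a carboxylic acid on the phenyl ring at this place would follow either number.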